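Aryl exchange from compound 3 to compound 4

This account rests on a few compounds, and the source may have more. Where it says the series, first, only, none or still open, it means among the compounds named here.

Measured in a functional assay on SGC-7901 cells (Homo sapiens) for inhibition, read by MTT assay, with a stated time of 24 h; a higher number here means a weaker inhibitor, a lower number a stronger inhibitor:
- compound 1 `CC1(C)[C@H]2CC[C@]1(C)N(Cc1cn(-c3cccc(F)c3)nn1)C(=O)C2` gives 530 nM
- compound 2 `CC1(C)[C@H]2CC[C@]1(C)N(Cc1cn(-c3ccc(C#N)cc3)nn1)C(=O)C2` gives 500 nM
- compound 3 `CC1(C)[C@H]2CC[C@]1(C)N(Cc1cn(-c3cccc(C#N)c3)nn1)C(=O)C2` gives 250 nM

Among the measured compounds shown here, compound 3 has the lowest of the three numbers, but it stands clear of only one compound. The data show a 2.1-fold lower number from compound 1 to compound 3 (0.33 log units; beyond the scatter) and also a 2.0-fold lower number from compound 2 to compound 3 (0.30 log units; within the scatter) (the latter is the closer comparison). The next structure is compound 4 `CC1(C)[C@H]2CC[C@]1(C)N(Cc1cn(-c3ccc(F)cc3)nn1)C(=O)C2`, with 4-fluorophenyl in place of 3-cyanophenyl on an aromatic nitrogen. For the measured compounds named here, no measured step makes this exact exchange. Two steps each cover part of it when read backwards: the exchange of fluoro and cyano (a 2.1-fold lower number from compound 1 to compound 3 (0.33 log units; beyond the scatter)) and the shift of the nitrile (a 2.0-fold lower number from compound 2 to compound 3 (0.30 log units; within the scatter)). Both are small, and the remaining step (a 1.1-fold lower number from compound 1 to compound 2 (0.03 log units; within the scatter)) adds no clear trend. From the compounds shown here alone, a modest rise in the number is therefore expected in this assay, and how far the two parts add up is unknown. The estimated change is a small one (a 2.6-fold higher number from compound 3 to compound 4 (0.41 log units; beyond the scatter)). For compound 4 the expected value is 650 nM, with an estimated range from 280 nM to 1400 nM.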

Compound 4, half-maximal inhibitory concentration: 500 nM
Estimate against measurement, compound 4: 1.3-fold (0.11 log units) above; the measured number falls inside the stated range.
By their numbers in this assay, from the lowest: compounds 3, 2, 4 and 1 (each within the scatter of the next, the first and the last beyond it).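

In this assay, the exchange at the aromatic nitrogen stays inside the scatter, a 2.0-fold higher number from compound 3 to compound 4 (0.30 log units; within the scatter). Fluoro in place of cyano on the 4-substituted ring gives no change at the digits printed from compound 2 to compound 4 (within the scatter), and 4-fluorophenyl in place of 3-fluorophenyl gives a 1.1-fold lower number from compound 1 to compound 4 (0.03 log units; within the scatter), so the only separation among these aryl groups remains that of 3-cyanophenyl from 3-fluorophenyl. Whether the cyano and fluoro exchange depends on where it sits on the ring cannot be told from these compounds: the same change on two cores in this assay, a 2.1-fold lower number (0.33 log units; beyond the scatter) from compound 1 to compound 3 and no change at the digits printed (within the scatter) from compound 4 to compound 2, 2.1-fold (0.33 log units) apart, within the scatter of two such steps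

Still open, from the compounds shown here alone, is whether any other group on this ring, such as a methoxy, an amine or a carboxylic acid, would give a number clearly apart from these four. Also open, going by these compounds, is how an unsubstituted phenyl on the same nitrogen compares.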